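A small swap on compound 1

A few compounds are considered here, and "the series" means these few. Any claim that something is new, unique, unknown or untested is made for them only; others in the source may bear on it.

- compound 1 `O=S(=O)(Nc1ncccn1)c1ccc2c(c1)OCC[C@@H]2c1ccc(C(F)(F)F)cc1-c1ccc(F)nc1` gives 2.8
- compound 2 `Cc1nc(-c2cc(C(F)(F)F)ccc2[C@@H]2CCOc3cc(S(=O)(=O)Nc4nccs4)ccc32)co1` gives 2.9
- compound 3 `Cn1nccc1-c1cc(C(F)(F)F)ccc1[C@H]1CCOc2cc(S(=O)(=O)Nc3nccs3)ccc21` gives 2.2

In a physicochemical assay for lipophilicity (a lower number here means a more polar compound, a higher number a more lipophilic compound), compound 1 gives 2.8 as its value, within the scatter of compound 2 at 2.9 and clearly apart from compound 3 at 2.2 on the lower side. Compound 4 `O=S(=O)(Nc1ncccn1)c1ccc2c(c1)OCC[C@@H]2c1ccc(C(F)(F)F)cc1-c1ccc(F)cn1` has 5-fluoropyridin-2-yl in place of 6-fluoropyridin-3-yl on an aromatic carbon of compound 1 (5-fluoropyridin-2-yl in place of 6-fluoropyridin-3-yl on an aromatic carbon), with the same atoms joined differently. Within the data shown here, no two measured compounds differ in one place only, which leaves no measured step as a guide. Only a small upward change, within the scatter, is expected (a number 0.10 log units higher from compound 1 to compound 4 (within the scatter)). In this assay compound 4 is estimated at 2.9 with a range from 2.4 to 3.3 expected.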

Compound 4, distribution coefficient: 2.9
Compound 4: middle estimate and measured number agree at the digits printed, within the range that was stated.
By their numbers in this assay, from the lowest: compound 3; then compounds 1, 2 and 4 (each within the scatter of the next).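

Among these compounds, this is the first step at this place, an aromatic carbon ortho to a large group, that changes one thing only. Putting 5-fluoropyridin-2-yl in place of 6-fluoropyridin-3-yl gives a number 0.10 log units higher from compound 1 to compound 4 (within the scatter) in this assay, so joining the same atoms differently leaves the two compounds indistinguishable here. Nothing at hand explains this result. The step covers one pair of isomeric fluoropyridines on one core. Going by these compounds, whether an amine or a carboxylic acid at this place would move the number beyond the scatter remains open.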